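Swapping fluorine for iodine on a calpain inhibitor core

This account rests on a few compounds, and the source may have more. Where it says the series, first, only, none or still open, it means among the compounds named here.

Of the compounds shown here, three sharing one core have been tested in an assay on isolated protein for inhibition of Calpain-1 catalytic subunit (Sus scrofa), read by FRET; on this read-out higher numbers stand for weaker inhibition and lower numbers for stronger inhibition. Compound 1, with the structure `O=C(O)/C(S)=C/c1c[nH]c2c(F)cccc12`, gives 120 nM. Compound 2, `O=C(O)/C(S)=C/c1c[nH]c2cc(F)ccc12`, carries its fluoro at another position of the same ring and gives 10 nM. Compound 3, `O=C(O)/C(S)=C/c1c[nH]c2ccc(I)cc12`, carries an iodo instead and gives 100 nM.

Among these three numbers compound 1 stands highest. Its nearest neighbour is compound 3, whose number is lower by an amount that lies within the usual scatter of repeated measurements, so the two cannot be told apart. Its furthest neighbour is compound 2, whose number is lower by an amount well beyond that scatter.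

Compound 4, `O=C(O)/C(S)=C/c1c[nH]c2c(I)cccc12`, has not yet been measured. It differs from compound 1 in one place: iodo in place of fluoro on an aromatic carbon. Among the measured compounds shown here, no measured pair shows this exact change, so the size of the step can only be guessed. The fact that compound 3, which also carries an iodo on the core, sits within the scatter of compound 1 suggests that iodine on this ring need not move the number far. The expectation is therefore a step from compound 1 to compound 4 of about a 1.2-fold lower number from compound 1 to compound 4 (0.08 log units; within the scatter), in no clear direction beyond the scatter. Compound 4 is estimated at 100 nM in this assay , with a likely range from 30 nM to 400 nM.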

Compound 4, half-maximal inhibitory concentration: 90 nM
Estimate against measurement, compound 4: 1.1-fold (0.05 log units) above, within the range that was stated.
By their numbers in this assay, from the lowest: compound 2; then compounds 4, 3 and 1 (each within the scatter of the next).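

In this assay, iodo in place of fluoro on this aromatic carbon, ortho to a fused ring, gives a 1.3-fold lower number from compound 1 to compound 4 (0.12 log units; within the scatter). Among the compounds shown here, this is the first direct reading of the change on the shared core, and it shows that at this place the two halogens cannot be told apart by this measurement: exchanging one for the other leaves no step that stands clear of the ordinary variation between repeated measurements. Nothing available here accounts for why the two halogens read alike at this place.

The compounds shown carry only halogens on the six-membered ring, so what a plain hydrogen, an amine or a methoxy group would do at this same carbon remains open, and such groups could reveal whether this place responds to any change at all. Also open, from the compounds shown here alone, is whether iodo in place of fluoro would give an equally small step at another carbon of the ring, a question that needs a pair of compounds differing only in that one group at that other place.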